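The compounds below may be only part of what the source reports. "The series", "measured", "known", "first", "only" and "open" are said of these compounds alone.

The compounds measured so far:

Compound 1, `Clc1ccc(-n2nncc2-c2cccnc2)cc1`, in a functional assay on the whole organism with Mus musculus as the target (on this read-out lower numbers stand for an effect already at smaller amounts and higher numbers for an effect only at larger amounts of compound), compound 1 gives 27 mg/kg.
Compound 2, `FC(F)(F)c1ccc(-n2nncc2-c2cccnc2)cc1`, compound 2 gives 90.5 mg/kg.
Compound 3, `Fc1ccc(-n2nncc2-c2cccnc2)cc1`, compound 3 gives 47.9 mg/kg.

Compound 3 has the second highest of the three numbers; its nearest neighbour is compound 1, with a 1.8-fold higher number from compound 1 to compound 3 (0.25 log units; within the scatter), and its furthest is compound 2, with a 1.9-fold lower number from compound 2 to compound 3 (0.28 log units; within the scatter). Both of these steps stay within the scatter, so the three halogen-bearing and trifluoromethyl-bearing compounds cannot be ordered with confidence, apart from a 3.4-fold higher number from compound 1 to compound 2 (0.53 log units; beyond the scatter).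

Compound 4, `Brc1ccc(-n2nncc2-c2cccnc2)cc1`, differs from compound 3 by bromo in place of fluoro on an aromatic carbon. Among the measured compounds shown here, the step that bears most directly on this exchange of one halogen for another is the one from compound 1 to compound 3, which stayed within the scatter. A step of similar size, towards a somewhat lower number, is therefore expected: a 1.4-fold lower number from compound 3 to compound 4 (0.14 log units; within the scatter). For compound 4 the estimated value is 35 mg/kg, with a range from 15 mg/kg to 80 mg/kg.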

Compound 4, dose for half-maximal effect: 40.7 mg/kg
Estimate against measurement, compound 4: 1.2-fold (0.07 log units) below; measured number inside the range.
By their numbers in this assay, from the lowest: compounds 1, 4, 3 and 2 (each within the scatter of the next, the first and the last beyond it).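

In this assay, bromo on this aromatic carbon, para to a large group, cannot be separated from the other halogens, since a 1.2-fold lower number from compound 3 to compound 4 (0.07 log units; within the scatter) and a 1.5-fold higher number from compound 1 to compound 4 (0.18 log units; within the scatter). Trifluoromethyl now stands apart from a second halogen, with a 2.2-fold lower number from compound 2 to compound 4 (0.35 log units; beyond the scatter), although compound 3 remains within the scatter of compound 2. No evidence is at hand to explain these numbers. Going by these compounds, whether an amine, a methoxy group or a carboxylic acid at this position would give a number outside those of the four compounds stays open. Also open, on these data alone, is how a group at another place on this ring would behave.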